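Aryl swap on the pyrrolidine of compound 1

The source may report more compounds than this note shows. Statements on the series, on what has been measured and on what is new or still open speak of the compounds shown alone.

Within the data shown here, compound 1 `CC(C)[C@H](NC(=O)CCN(C)C)c1cccc(F)c1N1CCN(C(=O)[C@@H]2CN(C(C)C)C[C@H]2c2ccc(Cl)cc2)CC1` gives the higher of the two numbers so far in an assay on HEK293 cells for displacement of a labelled ligand from Melanocortin receptor 4 (Homo sapiens) (a higher number here means a weaker inhibitor, a lower number a stronger inhibitor), with 5.3 nM; compound 2 `Cc1ccc(N2CCN(C(=O)[C@@H]3CN(C4CCOCC4)C[C@H]3c3ccc(Cl)cc3)CC2)c([C@@H](NC(=O)[C@H](C)N)C(C)C)c1` gives 1 nM in this assay, a gap that lies beyond the scatter. Compound 3 `CC(C)[C@H](NC(=O)CCN(C)C)c1cccc(F)c1N1CCN(C(=O)[C@@H]2CN(C(C)C)C[C@H]2c2cccc(F)c2)CC1` differs from compound 1 by 3-fluorophenyl in place of 4-chlorophenyl on a saturated ring carbon. Among the measured compounds shown here, no pair of measured compounds shows this change, so the size of the step is open on these data. A moderate weakening is expected, a 2.8-fold higher number from compound 1 to compound 3 (0.45 log units; beyond the scatter). In this assay compound 3 is estimated at 15 nM, within a range of 5 nM to 60 nM.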

Compound 3, inhibition constant: 560 nM
Estimate against measurement, compound 3: 37-fold (1.57 log units) below; measured number outside the range, above it.
By their numbers in this assay, from the lowest: compound 2; then compound 1; then compound 3.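

In this assay, the aryl group on this saturated ring carbon carries much of the affinity: 3-fluorophenyl in place of 4-chlorophenyl gives a 110-fold higher number from compound 1 to compound 3 (2.02 log units; beyond the scatter), although the heavy-atom count, hydrogen-bond donors and acceptors, and net charge are unchanged. The earlier compounds shown here both carry 4-chlorophenyl, so they gave no view of this position. Nothing measured here accounts for the size of this step.

The step combines two changes, the halogen and its place on the ring; 4-fluorophenyl or 3-chlorophenyl on the core of compound 1 would separate them. Going by these compounds, whether a step of this size also holds on the core of compound 2 remains open.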